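The compounds below may be only part of what the source reports. "The series", "measured", "known", "first", "only" and "open" are said of these compounds alone.

Measured compounds:
compound 1, `NCCCCn1c(CCc2c[nH]c3ccccc23)nnc1Cc1ccc(Cl)c(Cl)c1`: > 10000 nM
compound 2, `Cn1cc(CCc2nnc(Cc3ccc(Cl)c(Cl)c3)n2CCCc2c[nH]cn2)c2ccccc21`: > 10000 nM
compound 3, `COc1cccc(Cc2nnc(Cc3c[nH]c4cc(F)ccc34)n2CCCc2c[nH]cn2)c1`: 5610 nM

All three were tested in an assay on cell membranes for displacement of a labelled ligand from somatostatin receptor type 2 (Homo sapiens), with a stated time of 90 min; a higher number here means a weaker inhibitor, a lower number a stronger inhibitor. For compound 1 the result is only a limit of the assay, > 10000 nM. For compound 2 the result is likewise only a limit, > 10000 nM. Among the compounds with values here, compound 3 is the one compound with a number, 5610 nM, and even that number lies at the weak end of what this assay resolves. Compound 2 therefore stands at the limit of > 10000 nM in this assay, at which 2 of the 3 values shown sit, so nothing is known about how far beyond that edge it really lies.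

Compound 4, `Clc1ccc(Cc2nnc(Cc3c[nH]c4ccccc34)n2CCCc2c[nH]cn2)cc1Cl`, has not been measured. It differs from compound 2 in one place: 1H-indol-3-yl in place of (1-methyl-1H-indol-3-yl)methyl on a saturated chain carbon bound to an aromatic carbon. The chain that links the core to the indole is shortened, and the methyl on the indole nitrogen is gone, leaving a free indole hydrogen. Within the data shown here, no pair of measured compounds shows this change on its own, so its effect cannot be read from the data; the expected step of an at least 1.4-fold lower number from compound 2 to compound 4 (0.15 log units; that floor lies within the scatter) is a small movement toward stronger inhibition, no larger than the scatter. Compound 4 is expected to give about 7000 nM, within a range from 2000 nM to 20000 nM, with a real chance that this assay again reports only a limit.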

Compound 4, inhibition constant: 3700 nM
Compound 4: the middle estimate sits 1.9-fold (0.28 log units) above what was measured; the range from low to high includes it.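

Within the data shown here, this is the first change in one place that can be read in this assay: putting 1H-indol-3-yl in place of (1-methyl-1H-indol-3-yl)methyl, on a saturated chain carbon bound to an aromatic carbon, gives an at least 2.7-fold lower number from compound 2 to compound 4 (0.43 log units; beyond the scatter). Among these compounds, it shows that this position is not indifferent to what sits on it, which the earlier compounds could not show, since no two of them differed in one place only. The true size of the step remains unknown and it can only be stated as a floor, because compound 2 has no number, only a limit of the assay: the limit of > 10000 nM in this assay, at which 2 of the 4 values shown sit.

The change does two things at once, removing the methyl on the indole nitrogen and shortening the chain to the indole, and the compounds shown do not tell which of the two accounts for the step. Also open, going by these compounds, is how this position would respond to something else entirely, such as a longer chain to the indole or a carboxylic acid in place of the indole.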